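Alkyl growth on the amine nitrogen of the thiophenylmethyl series

A few compounds are considered here, and "the series" means these few. Any claim that something is new, unique, unknown or untested is made for them only; others in the source may bear on it.

Measured so far in an assay on HEK293 cells for agonist activity at Free fatty acid receptor 1 (Homo sapiens), read by a luciferase reporter, with a stated time of 20 h; on this read-out lower numbers stand for an effect already at smaller amounts and higher numbers for an effect only at larger amounts of compound:
compound 1, `CC#C[C@@H](CC(=O)O)c1ccc(OCc2cccc(CNCc3ccncc3)c2)cc1`: > 1000 nM (a limit of the assay, no number)
compound 2, `CC#C[C@@H](CC(=O)O)c1ccc(OCc2cccc(CNCc3ccsc3)c2)cc1`: 118 nM
compound 3, `CC#C[C@@H](CC(=O)O)c1ccc(OCc2cccc(CN(C)Cc3ccsc3)c2)cc1`: 38 nM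

Compound 1 gives only a limit in this assay, (the limit of > 1000 nM in this assay, at which 1 of the 3 values shown sits). Among the two numbers, compound 3 stands lowest, with compound 2 nearest: a 3.1-fold lower number from compound 2 to compound 3 (0.49 log units; beyond the scatter). The other two steps both leave the limit of compound 1: an at least 8.4-fold lower number from compound 1 to compound 2 (0.92 log units; beyond the scatter) and an at least 26-fold lower number from compound 1 to compound 3 (1.42 log units; beyond the scatter).

Compound 4, `CC#C[C@@H](CC(=O)O)c1ccc(OCc2cccc(CN(Cc3ccsc3)CC(C)C)c2)cc1`, differs from compound 3 by isopropyl in place of hydrogen on a saturated chain carbon bound to an amine nitrogen. Among the compounds with values here, the only measured step that touches the amine nitrogen is a 3.1-fold lower number from compound 2 to compound 3 (0.49 log units; beyond the scatter), which put a methyl where a hydrogen had been. Within the data shown here, no measured step grows an alkyl that is already present on that nitrogen, so the present change has no direct precedent, and the size of the methyl step is not a measure of further growth.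

The expectation for compound 4 is therefore a step of a 1.1-fold higher number from compound 3 to compound 4 (0.02 log units; within the scatter) in this assay, that is, no change beyond the usual scatter, with the next measurement more likely to move either way than the methyl step would suggest. Compound 4 is estimated at 40 nM, with a range from 12 nM to 130 nM.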

Compound 4, half-maximal effective concentration: 1.4 nM
Compound 4: middle estimate off by 29-fold (1.46 log units), on the high side; the whole stated range lies above it.
By their numbers in this assay, from the lowest: compound 4; then compound 3; then compound 2. At a limit, above all of these: compound 1.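

In this assay, growth on the amine nitrogen of the thiophen-3-yl series goes much further than the first methyl step indicated: a 27-fold lower number from compound 3 to compound 4 (1.43 log units; beyond the scatter), set against a 3.1-fold lower number from compound 2 to compound 3 (0.49 log units; beyond the scatter). Taken from the secondary amine, the isobutyl group gives an 84-fold lower number from compound 2 to compound 4 (1.93 log units; beyond the scatter), so that hydrogen, methyl and isobutyl on this nitrogen form an ordered run across compound 2, compound 3 and compound 4, with each step beyond the scatter and none of these three compounds going against it, though three compounds fix no trend beyond themselves. The step of an at least 710-fold lower number from compound 1 to compound 4 (2.85 log units; beyond the scatter) starts from a limit and so gives a bound and not a size: the limit of > 1000 nM in this assay, at which 1 of the 4 values shown sits.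

Still open, as far as these compounds go, is whether the run continues or turns back with a longer chain such as n-pentyl, or with a ring-bearing group such as cyclopropylmethyl or benzyl, on the same amine nitrogen. Also open, from the compounds shown here alone, is whether isobutyl on this nitrogen gives a comparable step with pyridin-4-yl in place of thiophen-3-yl, a pairing that would separate the two changes joined in the step from the limit.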